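The source may hold more compounds than are shown below. What is called first, only, known or untested is meant among the compounds shown, and "the series" means these compounds.

Among the compounds with values here, in a functional assay on ECa-109 cells (Homo sapiens) for cytotoxicity, read by MTT assay, with a stated time of 48 h (a lower number here means a stronger inhibitor, a higher number a weaker inhibitor), compound 1 (`COc1ccc(-c2c(-c3cc(OC)c(OC)c(OC)c3)noc2N)cc1`) gives 5840 nM, the lower of the two numbers measured so far, while compound 2 (`COc1ccc(-c2c(-c3cc(OC)c(OC)c(OC)c3)noc2N)cc1OC`) gives 20600 nM. The next compound to be tested is compound 3 (`COc1cc(-c2noc(N)c2-c2ccc(Cl)cc2)cc(OC)c1OC`). Its structural change from compound 1 is chloro in place of methoxy on an aromatic carbon, which means chloro in place of methoxy on an aromatic carbon, turning 4-methoxyphenyl into 4-chlorophenyl. Within the data shown here, only one measured step bears on this change: a 3.5-fold higher number from compound 1 to compound 2 (0.55 log units; beyond the scatter), seen with methoxy in place of hydrogen on an aromatic carbon. Among the measured compounds shown here, that modest step added a methoxy and did not exchange one, so it is only a loose guide, and no measured step shows the effect of chloro. The estimated change is a 1.1-fold lower number from compound 1 to compound 3 (0.03 log units; within the scatter), which means no shift beyond the scatter is expected. For compound 3, the expected value is 5500 nM, with an estimated range of 1700 nM to 18000 nM.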

Compound 3, half-maximal inhibitory concentration: > 50000 nM
Compound 3: only a limit was reported; the forecaster's own chance of this, stated with the estimate: 3%; middle value at least 9.0-fold (0.95 log units) away from the limit.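

In this assay, the earlier step showed only that adding a methoxy raises the number, whereas exchanging the methoxy of the 4-methoxyphenyl group for chloro gives an at least 8.5-fold higher number from compound 1 to compound 3 (0.93 log units; beyond the scatter), so this place, para to a large group, does not accept every replacement. Compound 3 is reported only as a limit, > 50000 nM, and not as a number. The step therefore gives a minimum size and not an exact one, because the reading for compound 3 stops at this point: the limit of > 50000 nM in this assay, at which 1 of the 3 values shown sits.

The compounds shown cannot separate the effect of bringing in chloro from that of losing the methoxy. From the compounds shown here alone, it also remains open how other groups in this place would read, such as a fluoro, a hydroxyl, an amine or a longer chain like ethoxy.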